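The compounds below may be only part of what the source reports. "The series", "measured", "known", "first", "only" and "open" are said of these compounds alone.

Measured in a physicochemical assay for lipophilicity, at pH 7.4; a higher number here means a more lipophilic compound, a lower number a more polar compound:
- compound 1 `COc1ccc(C2(C(=O)N3CCC[C@@H]3C(=O)Nc3ccc4[nH]ncc4n3)CCC2)cc1`: 3.9
- compound 2 `O=C(Nc1ccc2[nH]c(=O)[nH]c2c1)[C@H]1CCCN1C(=O)C1(c2cccc(Cl)c2)CCCC1`: 4.4

Compound 2, at 4.4, holds the higher of the two numbers, and compound 1, at 3.9, lies lower by a gap beyond the usual scatter. These two compounds differ in more than one place, so their gap does not isolate the effect of any single change.

Compound 3 `CNC(=O)c1cccc(NC(=O)[C@H]2CCCN2C(=O)C2(c3cccc(Cl)c3)CCCC2)c1` has not yet been measured. It departs from compound 2 in one place, on an amide-type nitrogen: a group of 10 heavy atoms (8 carbon, 1 nitrogen, 1 oxygen; one six-membered aromatic ring of carbon only) in place of a group of 10 heavy atoms (7 carbon, 2 nitrogen, 1 oxygen; one five-membered aromatic ring with 2 hetero atoms, one six-membered aromatic ring of carbon only), on an amide-type nitrogen. A 3-(methylcarbamoyl)phenyl group enters there, in place of a group with no common name that holds a five-membered aromatic ring with 2 hetero atoms and a six-membered aromatic ring of carbon only.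

For the measured compounds named here, no measured pair shows a comparable single change, so the expectation is cautious and starts from compound 2 at 4.4. In this assay the expected change is small and slightly downward, not beyond the scatter: the estimated step is a number 0.10 log units lower from compound 2 to compound 3 (within the scatter). For compound 3 the estimate is 4.3, with an expected range from 3.8 to 4.8.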

Compound 3, distribution coefficient: 5.5
Estimate against measurement, compound 3: 1.20 log units below; measured number above the stated range.
By their numbers in this assay, from the lowest: compound 1; then compound 2; then compound 3.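

In this assay, the exchange on the amide-type nitrogen gives a large move, a number 1.10 log units higher from compound 2 to compound 3 (beyond the scatter), which shows that this position can strongly shift the read-out, something the first two compounds, differing in more than one place, could not isolate. The move comes with no change in size by heavy-atom count, as the entering 3-(methylcarbamoyl)phenyl group and the leaving group each hold 10 heavy atoms, so a group of equal heavy-atom count at this place does not guarantee a similar number. The two groups do differ in other counted features, with 1 hydrogen-bond donor in the entering group against 2 in the leaving group, and only the leaving group holds a five-membered aromatic ring with 2 hetero atoms, but nothing available explains the step or assigns it to any one of these differences.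

The compounds shown leave open whether the step belongs to the six-membered carbon ring itself or to the methylcarbamoyl group it carries, a question that an unsubstituted phenyl group on the same nitrogen could address. They also leave open how a carboxylic acid or an amine in place of the methylcarbamoyl group would read, and whether the same exchange gives a step of similar size on the core of compound 1.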